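This account rests on a few compounds, and the source may have more. Where it says the series, first, only, none or still open, it means among the compounds named here.

Compound 3 `CCCCCn1c(N)nc2c(CC)cccc21` stands lowest of the two numbers in an assay on HEK293 cells for agonist activity at Toll-like receptor 8 (Homo sapiens), read by reporter gene assay (on this read-out lower numbers stand for an effect already at smaller amounts and higher numbers for an effect only at larger amounts of compound), where compound 3 gives 1650 nM; compound 1 `CCCCCn1c(N)nc2ccccc21` gives 3230 nM, and a 2.0-fold lower number from compound 1 to compound 3 (0.29 log units; within the scatter), so the two are not separated. Compound 2 `CCCCCn1c(N)nc2c(C(F)(F)F)cccc21` is recorded in this assay as "not active" (no number reported), without a number. Compound 4 `CCCCCn1c(N)nc2c(N(C)C)cccc21` differs from compound 3 by dimethylamino in place of ethyl on an aromatic carbon. For the measured compounds named here, no measured step covers this change; the only step, a 2.0-fold lower number from compound 1 to compound 3 (0.29 log units; within the scatter), alters the same aromatic carbon and stays within the scatter, while compound 2 shows that another group at that aromatic carbon went with no measurable activity. On this assay the expected step is therefore a 1.1-fold higher number from compound 3 to compound 4 (0.04 log units; within the scatter), with wide uncertainty in both directions. Compound 4 is estimated at 1800 nM, range 400 nM to 8000 nM.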

Compound 4, half-maximal effective concentration: 7120 nM
Compound 4: middle estimate off by 4.0-fold (0.60 log units), on the low side; the range from low to high includes it.
By their numbers in this assay, from the lowest: compounds 3 and 1 (each within the scatter of the next); then compound 4.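

In this assay dimethylamino on this aromatic carbon gives a 4.3-fold higher number from compound 3 to compound 4 (0.63 log units; beyond the scatter) and also a 2.2-fold higher number from compound 1 to compound 4 (0.34 log units; beyond the scatter) so, unlike the change to ethyl, this change moves the number beyond the scatter in both comparisons. Compound 4 still has a number, whereas compound 2, with trifluoromethyl at the same carbon, is recorded as not active, so a larger number here need not mean a loss of measurable activity. No evidence bears on why dimethylamino behaves this way.

Open, going by these compounds, is how a primary amine, a methoxy group or a propyl chain on this carbon would compare with ethyl and dimethylamino. Also open, on these data alone, is whether dimethylamino would give a similar step on another aromatic carbon of the shared core.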